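The source may report more compounds than this note shows. Statements on the series, on what has been measured and on what is new or still open speak of the compounds shown alone.

Working notes on the series. In a functional assay on A549 cells (Homo sapiens) for inhibition, read by MTT assay, with a stated time of 48 h (a higher number here means a weaker inhibitor, a lower number a stronger inhibitor), compound 1 (`Cc1ccc(NC(=O)Nc2cccc(-c3cccc4[nH]nc(N)c34)c2)cc1Cl`) gives 1750 nM, compound 2 (`Nc1n[nH]c2cccc(-c3cccc(NC(=O)Nc4cccc(F)c4)c3)c12`) gives 1360 nM and compound 3 (`CC(C)c1cccc(NC(=O)Nc2cccc(-c3cccc4[nH]nc(N)c34)c2)c1`) gives 1420 nM. Compound 3 thus stands level with the other two, and all three values lie within the scatter of each other. The measured steps are all small: a 1.3-fold lower number from compound 1 to compound 2 (0.11 log units; within the scatter), a 1.2-fold lower number from compound 1 to compound 3 (0.09 log units; within the scatter) and a 1.0-fold higher number from compound 2 to compound 3 (0.02 log units; within the scatter).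

The next structure is compound 4 (`Nc1n[nH]c2cccc(-c3cccc(NC(=O)Nc4nccs4)c3)c12`), with 1,3-thiazol-2-yl in place of 3-isopropylphenyl on an amide-type nitrogen. The three steps above bear on this change, as all of them alter the group on the same nitrogen, but only in part. Each exchanges one substituted phenyl for another, and none brings in a five-membered aromatic ring with hetero atoms, so the data lack a direct comparison.

In this assay the expectation is therefore a small move toward a higher number, not beyond the scatter, with real uncertainty on both sides. The expected step is a 1.3-fold higher number from compound 3 to compound 4 (0.13 log units; within the scatter). Compound 4 is estimated at 1900 nM, with an expected range of 800 nM to 6000 nM.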

Compound 4, half-maximal inhibitory concentration: > 500000 nM
Compound 4: a limit, no number; the forecaster's own chance of this, stated with the estimate: 5%; middle value at least 260-fold (2.42 log units) from the limit.
By their numbers in this assay, from the lowest: compounds 2, 3 and 1 (each within the scatter of the next). At a limit, above all of these: compound 4.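

On the amide-type nitrogen, the exchanges among compounds 1, 2 and 3 showed a group that could change without any step beyond the scatter, but that tolerance does not extend to 1,3-thiazol-2-yl: in this assay the change gives an at least 350-fold higher number from compound 3 to compound 4 (2.54 log units; beyond the scatter), an at least 360-fold higher number from compound 2 to compound 4 (2.56 log units; beyond the scatter) and an at least 280-fold higher number from compound 1 to compound 4 (2.45 log units; beyond the scatter). The result for compound 4 is a limit, not a number: the limit of > 500000 nM in this assay, at which 1 of the 4 values shown sits. The position is therefore not indifferent to what it carries, and the tolerance seen so far holds only for the three substituted phenyl groups in compounds 1, 2 and 3, while the single five-membered aromatic ring with 2 hetero atoms, in compound 4, goes against it.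

The compounds shown leave open which part of the exchange carries this large step, the ring size or the ring nitrogen and sulfur, as the change alters these together. A thiophene ring or a pyridine ring on the same nitrogen would separate these two readings, and an unsubstituted phenyl would show whether any substituent on that ring is needed at all.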